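The source may hold more compounds than are shown below. What is called first, only, known or untested is meant among the compounds shown, and "the series" means these compounds.

Three compounds have been measured in an assay on isolated protein for inhibition of 2-Hydroxyacid oxidase 2 (Homo sapiens), tested at 1 uM; on this read-out lower numbers stand for a weaker effect and higher numbers for a stronger effect at the one concentration tested:

Compound 1, `Cc1n[nH]c(C(=O)O)c1Cc1cccc(-c2cccc(F)c2)c1`, gives 20%.
Compound 2, `Cc1n[nH]c(C(=O)O)c1Cc1cccc(-c2ccc(C#N)cc2)c1`, gives 13%.
Compound 3, `Cc1n[nH]c(C(=O)O)c1Cc1cccc(-c2ccccc2F)c1`, gives 5%.

Compound 2 stands second highest of these three numbers. Its nearest neighbour is compound 1: the step from compound 1 to compound 2 was a number 7 percentage points lower from compound 1 to compound 2 (within the scatter), so the two cannot be told apart. Its furthest neighbour is compound 3, and the step from compound 2 to compound 3 was a number 8 percentage points lower from compound 2 to compound 3 (within the scatter), again too small to count. Among the measured compounds shown here, only the step from compound 1 to compound 3, a number 15 percentage points lower from compound 1 to compound 3 (beyond the scatter), rises beyond the scatter.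

Compound 4, `Cc1n[nH]c(C(=O)O)c1Cc1cccc(-c2ccc(C(N)=O)cc2)c1`, differs from compound 2 in one place: carbamoyl in place of cyano on an aromatic carbon. For the measured compounds named here, no measured step exchanges one group for another on the same position of that outer ring; every step so far swaps the whole outer ring, and two of the three such swaps stayed within the scatter. There is thus nothing to suggest that exchanging cyano for carbamoyl would move the read-out far in either direction.

Compound 4 is therefore expected to sit close to compound 2, at an estimated 13%, with a likely range from 3% to 25%. The expected step from compound 2 to compound 4 in this assay is no change at the digits printed from compound 2 to compound 4 (within the scatter), that is, none beyond the scatter.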

Compound 4, a percentage reported as inhibition, at one concentration (the size of the read-out at that concentration, not a potency): 18%
Compound 4: middle estimate off by 5 percentage points, on the low side; measured number inside the range.
By their numbers in this assay, from the lowest: compounds 3, 2, 4 and 1 (each within the scatter of the next, the first and the last beyond it).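

Among the compounds shown here, this is the first step that keeps the outer ring and exchanges only the group on it: carbamoyl in place of cyano, on an aromatic carbon para to a large group. In this assay, that exchange gives a number 5 percentage points higher from compound 2 to compound 4 (within the scatter), so the two compounds cannot be told apart. At this position, then, going from 2 heavy atoms to 3 heavy atoms, from a triple bond to a double bond, and from 0 hydrogen-bond donors to 1 hydrogen-bond donor leaves no readable difference, and nothing at hand explains this result.

Open, going by these compounds, is whether any group at this position would rise beyond the scatter, for example an amine, a carboxylic acid or a methylsulfonyl group, or whether this place accepts many groups with little difference in the read-out. Also open, on these data alone, is whether the amide hydrogens matter here, which a carbamoyl group carrying a methyl on its nitrogen could test, and whether compound 2 and compound 4 would still match at other concentrations, since a single concentration gives no potency.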